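The source may report more compounds than this note shows. Statements on the series, on what has been measured and on what is new or still open speak of the compounds shown alone.

Measured so far in an ADME assay on a cell-free system (plasma, Mus musculus) for metabolic stability, read by LC-MS, tested at 2 uM; a lower number here means that the compound disappears faster, a higher number that the compound lasts longer:
- compound 1 `CC(C)N1CCC(c2ccc3c(c2)oc(=O)n3C(=O)NCCCCc2ccccc2)CC1`: 0.667 h
- compound 2 `CCN1CCN(c2ccc3c(c2)oc(=O)n3C(=O)NCCCCc2ccccc2)CC1`: < 0.0834 h

Compound 2 has no exact half-life, as compound 2 reads < 0.0834 h, which is a limit of the assay and not a number. This is the limit of < 0.0834 h in this assay, at which 1 of the 2 values shown sits. Compound 3 `CCN1CCC(c2ccc3c(c2)oc(=O)n3C(=O)NCCCCc2ccccc2)CC1` differs from compound 2 at one place, with 1-ethylpiperidin-4-yl in place of 4-ethylpiperazin-1-yl on an aromatic carbon.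

For the measured compounds named here, only one measured step bears on this change. It touches the same place, with 4-ethylpiperazin-1-yl replacing 1-isopropylpiperidin-4-yl, and it runs an at least 7.9-fold lower number from compound 1 to compound 2 (0.90 log units; beyond the scatter). The group entering compound 3 is also a piperidin-4-yl, so a rise of similar size is expected in this assay, well beyond the scatter. The expected step is an at least 5.9-fold higher number from compound 2 to compound 3 (0.77 log units; beyond the scatter). For compound 3 the estimated half-life is 0.5 h, with an expected range from 0.17 h to 1.5 h.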

Compound 3, half-life: 0.833 h
Compound 3: middle estimate off by 1.7-fold (0.22 log units), on the low side; low and high end bracket the measured number.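

In this assay, 1-ethylpiperidin-4-yl in place of 4-ethylpiperazin-1-yl, with the ethyl group kept, gives an at least 9.9-fold higher number from compound 2 to compound 3 (0.99 log units; beyond the scatter). This step starts from a limit of the assay and not from a number: the limit of < 0.0834 h in this assay, at which 1 of the 3 values shown sits.

The two piperidines, with isopropyl or ethyl on the amine nitrogen, differ by only a 1.2-fold higher number from compound 1 to compound 3 (0.10 log units; within the scatter), so among these compounds the short half-life goes with the piperazine ring and not with the size of that chain.

From the compounds shown here alone, whether a morpholin-4-yl group would fall with the 4-ethylpiperazin-1-yl group or stand with the piperidines remains open, as does the effect of a 1-methylpiperidin-4-yl group. How far the true half-life of compound 2 lies from its limit is also unknown, which leaves the full size of the step open.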